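Benzyl in Place of Phenyl on the Ring Nitrogen

A few compounds are considered here, and "the series" means these few. Any claim that something is new, unique, unknown or untested is made for them only; others in the source may bear on it.

Compound 1, `CN1CCN(CC(=O)Nc2ccc(-c3nc(-c4ccccc4)c(-c4ccccc4)n3C)cc2)CC1`, gives 1.1% in a functional assay on MCF7 cells (Homo sapiens) for cytotoxicity, read by MTT assay, with a stated time of 24 h, tested at 0.64 ug/mL; a higher number here means a stronger effect of the compound at the concentration tested, a lower number a weaker effect.
Compound 2, `CN(C)/C=C/N1CCN(CC(=O)Nc2ccc(-c3nc(-c4ccccc4)c(-c4ccccc4)n3C)cc2)CC1`, gives 1.2% in this assay.
Compound 3, `Cn1c(-c2ccc(NC(=O)CN3CCN(c4ccccc4)CC3)cc2)nc(-c2ccccc2)c1-c1ccccc1`, gives 12.1% in this assay.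

Compound 3 stands highest of the three numbers; its nearest neighbour is compound 2, and the gaps to compound 2 and to compound 1 both lie beyond the scatter. Within this small set, the group on the ring nitrogen is the only thing that changes. The step of a number 0.1 percentage points higher from compound 1 to compound 2 (within the scatter) lies within the scatter. Going by the values given here, two measured steps bear on the change that follows: a number 11 percentage points higher from compound 1 to compound 3 (beyond the scatter) and a number 10.9 percentage points higher from compound 2 to compound 3 (beyond the scatter), both modest rises that arrive at the phenyl group.

Compound 4, `Cn1c(-c2ccc(NC(=O)CN3CCN(Cc4ccccc4)CC3)cc2)nc(-c2ccccc2)c1-c1ccccc1`, has not yet been measured. The change is benzyl in place of phenyl on an amine nitrogen in a ring. Among the compounds with values here, no measured step exchanges phenyl for benzyl, so the direction of this step is not fixed by the data. Since the phenyl group gave compound 3 its modest rise of a number 11 percentage points higher from compound 1 to compound 3 (beyond the scatter), and the other groups on this nitrogen stayed low, the expectation is for compound 4 a modest fall, with wide uncertainty. Compound 4 is expected to give 7%, within 0% to 18%. For compound 4 the estimated step is a number 5.1 percentage points lower from compound 3 to compound 4 (within the scatter).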

Compound 4, a percentage reported as activity, at one concentration (the size of the read-out at that concentration, not a potency): 7.2%
Beside the measured number, compound 4's estimate is 0.2 percentage points below it, within the range that was stated.
By their numbers in this assay, from the lowest: compounds 1, 2, 4 and 3 (each within the scatter of the next, the first and the last beyond it).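

In this assay, benzyl in place of phenyl on the amine nitrogen in a ring gives a number 4.9 percentage points lower from compound 3 to compound 4 (within the scatter), so this exchange cannot be told apart from the scatter. The other two steps to compound 4 are also within the scatter, a number 6 percentage points higher from compound 2 to compound 4 (within the scatter) and a number 6.1 percentage points higher from compound 1 to compound 4 (within the scatter), so compound 4 cannot be separated from any of the other three compounds, whereas the gaps from compound 3 to compound 1 and compound 2 lie beyond the scatter. No measurement is at hand that would explain these numbers.

The compounds shown leave open how a 2-phenylethyl group, with its longer chain, or an acetyl group on this nitrogen would read out. They also leave open whether a benzyl ring bearing a fluorine or a methoxy group would separate from compound 3.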